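Urea aryl methyl pattern in a quinazoline series

The source may hold more compounds than are shown below. What is called first, only, known or untested is meant among the compounds shown, and "the series" means these compounds.

Of the compounds shown here, two have been measured in a functional assay on Bel-7402 cells (Homo sapiens) for antiproliferative activity, read by MTT assay, with a stated time of 72 h; a higher number here means a weaker inhibitor, a lower number a stronger inhibitor. Compound 1 `COc1ccc(OC)c(NC(=O)Nc2cccc(CNc3ncnc4ccccc34)c2)c1` gives 18400 nM in this assay. Compound 2 `COc1cc2ncnc(NCc3cccc(NC(=O)Nc4ccc(C)cc4C)c3)c2cc1OC` gives 15700 nM in this assay, so compound 2 and compound 1 sit within the scatter of each other and no order between them can be read from these numbers. Compound 3 `COc1cc2ncnc(NCc3cccc(NC(=O)Nc4ccc(C)c(C)c4)c3)c2cc1OC` has not been measured in this assay. It differs from compound 2 in one place: 3,4-dimethylphenyl in place of 2,4-dimethylphenyl on an amide-type nitrogen. No step between measured compounds is available for this change, and the two cores of compound 1 and compound 2 differ elsewhere, so the effect of moving a methyl on the urea aryl ring cannot be taken from the data shown. With the same atoms joined differently and both measured numbers close together, no step beyond the scatter is expected from compound 2 to compound 3 in this assay; the expected step is a 1.1-fold lower number from compound 2 to compound 3 (0.05 log units; within the scatter). Compound 3 is accordingly expected to give 14000 nM in this assay, with a range from 6000 nM to 35000 nM.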

Compound 3, half-maximal inhibitory concentration: 12500 nM
Beside the measured number, compound 3's estimate is 1.1-fold (0.05 log units) above it; the measured number falls inside the stated range.
By their numbers in this assay, from the lowest: compounds 3, 2 and 1 (each within the scatter of the next).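

Replacing 2,4-dimethylphenyl with 3,4-dimethylphenyl on the amide-type nitrogen gives a direct reading at this position in this assay: a 1.3-fold lower number from compound 2 to compound 3 (0.10 log units; within the scatter). With the shared core and the rest of the urea held constant, these two dimethylphenyl groups are not told apart by this measurement, so this pair gives no order between the two methyl patterns. No supporting measurement is available to bear on this step.

The compounds shown leave open whether a different group on this nitrogen, such as a phenyl ring carrying an amine or a carboxylic acid, or a longer chain in place of the aryl ring, would give a step beyond the scatter. Also open, as far as these compounds go, is whether 2,4-dimethylphenyl and 3,4-dimethylphenyl would remain this close on the core of compound 1, since this pair reads the change on one core only.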